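The compounds below may be only part of what the source reports. "The series", "measured", "known", "first", "only" and "open" are said of these compounds alone.

Compound 2 `COc1ccc(C2CC(c3ccccc3)=NN2C2=NC(=O)/C(=C3\C(=O)Nc4ccccc43)S2)cc1` was examined in a functional assay on cells (Melanoma cell, Homo sapiens) for cytotoxicity, read by sulforhodamine B assay, with a stated time of 48 h (on this read-out lower numbers stand for stronger inhibition of growth and higher numbers for weaker inhibition of growth), where compound 2 gives 4510 nM. Among the measured compounds shown here, of the two numbers measured so far, this is the highest. The nearest comparison is compound 1 `O=C1N=C(N2N=C(c3ccccc3)CC2c2ccccc2O)S/C1=C1/C(=O)Nc2ccc(Br)cc21`, which carries a bromo group on its fused ring system and a hydroxy group on its pendant phenyl; in this assay compound 1 gives 660 nM, a lower number than compound 2 and a gap that is beyond the scatter. Compound 1 and compound 2 differ in two places, so the two values alone cannot say which change drives that gap.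

Compound 3 `COc1ccc(C2CC(c3ccccc3)=NN2C2=NC(=O)/C(=C3\C(=O)Nc4ccc(Br)cc43)S2)cc1` probes one of these changes: bromo in place of hydrogen on an aromatic carbon. For the measured compounds named here, no single-point step has been measured for this change. Going by the values given here, since compound 1, the only bromo-bearing compound here, gives 660 nM, the step from compound 2 to compound 3 is expected to be a 2.5-fold lower number from compound 2 to compound 3 (0.40 log units; beyond the scatter), toward a lower number. Compound 3 is accordingly estimated to give 1800 nM in this assay, with a likely range from 700 nM to 4500 nM.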

Compound 3, concentration for total growth inhibition: 550 nM
For compound 3 the middle estimate is 3.3-fold (0.51 log units) above the measured one; the whole stated range lies above it.
By their numbers in this assay, from the lowest: compounds 3 and 1 (each within the scatter of the next); then compound 2.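

In this assay, among the compounds shown here, the change of bromo in place of hydrogen on an aromatic carbon, with all else held, gives an 8.2-fold lower number from compound 2 to compound 3 (0.91 log units; beyond the scatter) and so provides the first single-place reading of this position on the fused ring system. With bromo present, 4-methoxyphenyl in place of 2-hydroxyphenyl on a saturated ring carbon gives a 1.2-fold lower number from compound 1 to compound 3 (0.08 log units; within the scatter), so the two pendant groups are not told apart in this bromo-bearing pair. Nothing available explains the effect of the bromo group.

The compounds shown leave open whether chloro, fluoro, methyl or an amine on the same aromatic carbon would give a comparable step. They also leave open whether 2-hydroxyphenyl and 4-methoxyphenyl would remain so close with hydrogen in place of bromo.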